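Phenoxy to trifluoromethoxy: working notes

This account rests on a few compounds, and the source may have more. Where it says the series, first, only, none or still open, it means among the compounds named here.

Among the measured compounds shown here, compound 1 `COc1ccc(-c2cn(-c3ccc(Oc4ccccc4)cc3)nn2)cc1OC` holds the only plain number in the pair measured so far; in a functional assay on MDA-MB-231 cells (Homo sapiens) for cytotoxicity, read by MTT assay (a lower number here means a stronger inhibitor, a higher number a weaker inhibitor), compound 1 gives 10000 nM. Compound 2 `COc1ccc(-c2cn(-c3ccc(Oc4ccccc4)cc3)nn2)cc1O` differs by hydrogen in place of methyl on an oxygen on an aromatic ring. In this assay compound 2 gives > 10000 nM, a limit of the assay and not a number. The step of a number no lower from compound 1 to compound 2 (the limit leaves the size open) is therefore open in size. For the measured compounds named here, compound 3 `COc1ccc(-c2cn(-c3ccc(OC(F)(F)F)cc3)nn2)cc1OC` carries trifluoromethyl in place of phenyl on an oxygen on an aromatic ring, a change at a different place, so no measured step bears on it. Compound 3 is expected at 10000 nM, between 4000 nM and 25000 nM. The expected step of no change at the digits printed from compound 1 to compound 3 (within the scatter) stays within the scatter.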

Compound 3, half-maximal inhibitory concentration: > 1000 nM
Compound 3: a limit, no number (the forecaster's own chance of this, stated with the estimate: 50%); the middle value is on the limit's open side.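

In this assay, among the compounds shown here, compound 3 gives > 1000 nM, a limit and not a number, so no step from compound 1 can be read. The compounds shown leave open whether phenoxy to trifluoromethoxy shifts the read-out at all, and in which direction.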